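Terminal aryl substituent variation in a shared-core series

The source may hold more compounds than are shown below. What is called first, only, known or untested is meant among the compounds shown, and "the series" means these compounds.

Measured so far in a functional assay on HepG2 cells (Homo sapiens) for antiproliferative activity, read by MTT assay, with a stated time of 48 h; a higher number here means a weaker inhibitor, a lower number a stronger inhibitor:
compound 1 `O=C(Nc1cccc(CNc2nccnc2Cl)c1)Nc1ccccc1F` gives 10500 nM
compound 2 `O=C(Nc1ccc(Cl)cc1)Nc1cccc(CNc2nccnc2Cl)c1` gives 8350 nM
compound 3 `CC(C)(C)c1ccc(NC(=O)Nc2cccc(CNc3nccnc3Cl)c2)cc1` gives 7550 nM

Compound 3 gives the lowest of the three numbers, but its gaps to compound 2 and to compound 1 are both within the scatter, so no order among the three can be read from these values. Compound 4 `CS(=O)(=O)c1ccc(NC(=O)Nc2cccc(CNc3nccnc3Cl)c2)cc1` is yet to be measured in this assay. It differs from compound 3 in one place: methylsulfonyl in place of tert-butyl on an aromatic carbon.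

Within the data shown here, two measured steps bear on it. The change at the same aromatic carbon, a 1.1-fold lower number from compound 2 to compound 3 (0.04 log units; within the scatter), was within the scatter, and the exchange of the whole terminal ring, a 1.3-fold lower number from compound 1 to compound 2 (0.10 log units; within the scatter), was likewise within the scatter. Among the measured compounds shown here, no measured compound carries a methylsulfonyl group, so its own effect is unknown here. On this basis, in this assay a step of a 1.1-fold higher number from compound 3 to compound 4 (0.03 log units; within the scatter) is expected, meaning no shift beyond the scatter. Compound 4 is therefore estimated at 8000 nM, with a range from 3000 nM to 25000 nM.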

Compound 4, half-maximal inhibitory concentration: 15100 nM
For compound 4 the middle estimate is 1.9-fold (0.28 log units) below the measured one, within the range that was stated.
By their numbers in this assay, from the lowest: compounds 3, 2, 1 and 4 (each within the scatter of the next).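

In this assay, among these compounds, methylsulfonyl is the first group with hydrogen-bond acceptors at this aromatic carbon, para to a large group, and the exchange for tert-butyl gives a 2.0-fold higher number from compound 3 to compound 4 (0.30 log units; within the scatter) while the exchange for chloro gives a 1.8-fold higher number from compound 2 to compound 4 (0.26 log units; within the scatter) at the same carbon. Tert-butyl, chloro and methylsulfonyl differ in their atoms and acceptor counts, yet neither step separates methylsulfonyl from the other two groups at this position. Nothing available here accounts for these values.

From the compounds shown here alone, whether any group at this carbon can shift the number beyond the scatter stays open; an amine, a carboxylic acid or a longer alkyl chain there would test this. All four compounds share one core, so whether these steps hold on another core is also unknown.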